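A 4-(tert-butyl)phenyl group enters the shared core

The source may hold more compounds than are shown below. What is called first, only, known or untested is meant among the compounds shown, and "the series" means these compounds.

Measured in a functional assay on HCT-116 cells (Homo sapiens) for inhibition, read by CCK-8 assay, with a stated time of 48 h; on this read-out lower numbers stand for stronger inhibition and higher numbers for weaker inhibition:
Compound 1 `COc1cc(-c2ccnc3cc(-c4c[nH]c5ccccc45)nn23)cc(OC)c1OC`: 35 nM
Compound 2 `COc1ccc(-c2cc3nccc(-c4cc(OC)c(OC)c(OC)c4)n3n2)cc1N`: 251 nM

Compound 2 holds the higher of the two numbers. The change to compound 3 `COc1cc(-c2ccnc3cc(-c4ccc(C(C)(C)C)cc4)nn23)cc(OC)c1OC`, which has not yet been measured, is 4-(tert-butyl)phenyl in place of 3-amino-4-methoxyphenyl on an aromatic carbon. It falls on the same aromatic carbon of the five-membered aromatic ring that distinguishes compound 1 from compound 2. Among the compounds with values here, one measured step bears on it: a 7.2-fold higher number from compound 1 to compound 2 (0.86 log units; beyond the scatter). Within the data shown here, that step shows that exchange at this carbon can move the number beyond the scatter, but no measured compound carries 4-(tert-butyl)phenyl, so the direction remains uncertain. A modest move toward a higher number in this assay, smaller than that step, is the tentative expectation. The expected change is a 2.4-fold higher number from compound 2 to compound 3 (0.38 log units; beyond the scatter). Compound 3 is estimated at 600 nM, with an expected range from 120 nM to 2500 nM.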

Compound 3, half-maximal inhibitory concentration: > 10000 nM
Compound 3: no number, only a limit; the forecaster's own chance of this, stated with the estimate: 10%; at least 16-fold (1.22 log units) between middle value and limit.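

Exchange at this aromatic carbon of the five-membered ring can move the number much further than the earlier compounds showed: in this assay, 4-(tert-butyl)phenyl gives an at least 39-fold higher number from compound 2 to compound 3 (1.60 log units; beyond the scatter), and set against 1H-indol-3-yl it gives an at least 280-fold higher number from compound 1 to compound 3 (2.45 log units; beyond the scatter). As far as these compounds go, compound 3 has only a limit and no number, so the true size of both steps stays open: the limit of > 10000 nM in this assay, at which 1 of the 3 values shown sits. Both 3-amino-4-methoxyphenyl and 4-(tert-butyl)phenyl hold a six-membered aromatic ring of carbon only, so that ring alone does not keep the number low, and what it carries matters.

The compounds shown do not separate the loss of the amine and the methoxy group from the gain of the tert-butyl group. A phenyl ring bearing only an amine, only a methoxy group or only a methyl group at this carbon would begin to tell these apart.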